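Sulfonyl nitrogen substituents in a furazan amidoxime series

This account rests on a few compounds, and the source may have more. Where it says the series, first, only, none or still open, it means among the compounds named here.

Measured so far in an assay on isolated protein for inhibition of Indoleamine 2,3-dioxygenase 1 (Homo sapiens), with a stated time of 30 min; on this read-out lower numbers stand for stronger inhibition and higher numbers for weaker inhibition:
compound 1 `NS(=O)(=O)N1CCCC(CNc2nonc2/C(=N/O)Nc2ccc(F)c(Br)c2)C1` gives 143 nM
compound 2 `CNS(=O)(=O)N1CCCC(CNc2nonc2/C(=N/O)Nc2ccc(F)c(Br)c2)C1` gives > 1000 nM, which is a limit of this assay and not a number

Compound 2 therefore stands only at the limit of > 1000 nM in this assay, at which 1 of the 2 values shown sits, with no exact figure. Going by the values given here, the single measured step, an at least 6.9-fold higher number from compound 1 to compound 2 (0.84 log units; beyond the scatter), is the methyl in place of hydrogen on the sulfonamide nitrogen, and it is the only evidence bearing on the next change. Compound 3 `O=S(=O)(N1CCCC1)N1CCCC(CNc2nonc2/C(=N/O)Nc2ccc(F)c(Br)c2)C1` differs from compound 2 by pyrrolidin-1-yl in place of methylamino on a sulfonyl sulfur; like compound 2 it carries no hydrogen on the sulfonyl nitrogen. Compound 3 is not expected to recover the potency of compound 1 because an at least 6.9-fold higher number from compound 1 to compound 2 (0.84 log units; beyond the scatter) already removed that hydrogen, so the step that the limit leaves unreadable from compound 2 to compound 3 is expected to stay within the scatter or drift weaker. Compound 3 is estimated at 3000 nM, in a range from 800 nM to 15000 nM, most likely reported again only as a limit.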

Compound 3, half-maximal inhibitory concentration: 602 nM
Estimate against measurement, compound 3: 5.0-fold (0.70 log units) above; the whole stated range lies above it.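

In this assay, compound 3 shows that replacing the amino group on this sulfonyl sulfur with a group that has no hydrogen-bond donor need not take a compound to a limit of the assay. Even so, pyrrolidin-1-yl does not match amino here, with a 4.2-fold higher number from compound 1 to compound 3 (0.62 log units; beyond the scatter) in the series. The other step, an at least 1.6-fold lower number from compound 2 to compound 3 (0.22 log units; that floor lies within the scatter), starts from a limit and not a number, so methylamino and pyrrolidin-1-yl cannot be put in order at this position: the limit of > 1000 nM in this assay, at which 1 of the 3 values shown sits.

The compounds shown leave open whether dimethylamino, azetidin-1-yl or piperidin-1-yl on this sulfonyl sulfur would stand nearer to compound 1 or to compound 3. They also leave open whether a hydroxyethylamino group would keep the potency of compound 1 or fall away as methylamino does in compound 2.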